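A few compounds are considered here, and "the series" means these few. Any claim that something is new, unique, unknown or untested is made for them only; others in the source may bear on it.

Three analogues built on one shared core have been measured. Compound 1 `COc1cc(N)c(Cl)cc1NC(=O)C1CCN(CC2CCCCC2)CC1` carries cyclohexyl on a saturated chain carbon bound to an amine nitrogen in a ring, and in a functional assay on the whole organism for antagonist activity, with Mus musculus as the target (a lower number here means that less compound is needed, a higher number that more compound is needed for the effect), compound 1 gives 2.9 mg/kg. Compound 2 `COc1cc(N)c(Cl)cc1NC(=O)C1CCN(Cc2ccc(Cl)cc2)CC1` carries 4-chlorophenyl in that place, and in this assay compound 2 gives 1.2 mg/kg. Compound 3 `CCCCCN1CCC(C(=O)Nc2cc(Cl)c(N)cc2OC)CC1` carries butyl there. In this assay compound 3 reaches only a limit of the assay, > 10 mg/kg. Both measured steps ending at compound 3 run toward higher numbers: an at least 3.4-fold higher number from compound 1 to compound 3 (0.53 log units; beyond the scatter) and an at least 8.3-fold higher number from compound 2 to compound 3 (0.92 log units; beyond the scatter). Compound 4 `COc1cc(N)c(Cl)cc1NC(=O)C1CCN(Cc2ccsc2)CC1` differs from compound 3 by thiophen-3-yl in place of butyl on a saturated chain carbon bound to an amine nitrogen in a ring. Because an at least 8.3-fold higher number from compound 2 to compound 3 (0.92 log units; beyond the scatter) also set an aromatic ring against butyl, compound 4 is expected to need less compound, by an at least 5.0-fold lower number from compound 3 to compound 4 (0.69 log units; beyond the scatter). Compound 4 is estimated at 2 mg/kg, within 0.8 mg/kg to 6 mg/kg.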

Compound 4, dose for half-maximal effect: 3.4 mg/kg
Beside the measured number, compound 4's estimate is 1.7-fold (0.23 log units) below it; the range from low to high includes it.
By their numbers in this assay, from the lowest: compound 2; then compounds 1 and 4 (each within the scatter of the next). At a limit, above all of these: compound 3.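

In this assay, thiophen-3-yl gives a measurable value where butyl does not, an at least 2.9-fold lower number from compound 3 to compound 4 (0.46 log units; beyond the scatter), but this step is only a bound, since compound 3 stands at a limit of the assay: the limit of > 10 mg/kg in this assay, at which 1 of the 4 values shown sits.

Thiophen-3-yl does not match 4-chlorophenyl, a 2.8-fold higher number from compound 2 to compound 4 (0.45 log units; beyond the scatter), so an aromatic ring at this place does not by itself give the lowest number seen. Against cyclohexyl the step, a 1.2-fold higher number from compound 1 to compound 4 (0.07 log units; within the scatter), stays within the scatter, so a ring that is not aromatic serves as well here.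

Left open is how an unsubstituted phenyl or a pyridine ring would stand at this place, and so whether the gap to 4-chlorophenyl belongs to the chlorine or to the ring itself.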